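Methyl Added to the Unsaturated Chain of an Amide

This account rests on a few compounds, and the source may have more. Where it says the series, first, only, none or still open, it means among the compounds named here.

Three amide-bearing compounds were tested in a functional assay on A549 cells (Homo sapiens) for antiproliferative activity, read by MTT assay, with a stated time of 72 h; on this read-out higher numbers stand for weaker inhibition and lower numbers for stronger inhibition. Compound 1, with the structure `CC/C=C/C(=O)Nc1cc2c(N3CCc4ccccc43)ncnc2cc1OC`, gives 2470 nM. Compound 2, with the structure `COc1cc2ncnc(N3CCc4ccccc43)c2cc1NC(=O)/C=C/C(C)C`, gives 6410 nM. The step from compound 1 to compound 2 is methyl in place of hydrogen on a saturated chain carbon bound to a double-bonded chain carbon and a saturated chain carbon, and it produced a 2.6-fold higher number from compound 1 to compound 2 (0.41 log units; beyond the scatter). Compound 3, with the structure `C/C=C/C(=O)Nc1cc2c(N3CCCc4ccccc43)ncnc2cc1OC`, gives 8190 nM; the core of compound 3 and the core of compound 1 are built from the same atoms joined differently, and that difference between the two cores is not broken down here.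

Compound 4, with the structure `CC/C=C/C(=O)Nc1cc2c(N3CCCc4ccccc43)ncnc2cc1OC`, has not yet been measured. Compared with compound 3 it carries methyl in place of hydrogen on a saturated chain carbon bound to a double-bonded chain carbon. For the measured compounds named here, this is the same kind of change as the one from compound 1 to compound 2, not the same change: in the earlier pair the saturated chain carbon that receives the methyl is bound to a double-bonded chain carbon and a saturated chain carbon, while in compound 4 it is bound to a double-bonded chain carbon only.

Because the earlier methyl addition gave a 2.6-fold higher number from compound 1 to compound 2 (0.41 log units; beyond the scatter), the step from compound 3 to compound 4 in this assay is expected to be a 1.5-fold higher number from compound 3 to compound 4 (0.17 log units; within the scatter), a modest move toward weaker inhibition, though resting on a single precedent with a different core. Compound 4 is therefore estimated to give 12000 nM in this assay, with a plausible range from 5000 nM to 28000 nM.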

Compound 4, half-maximal inhibitory concentration: 5030 nM
Compound 4: the middle estimate sits 2.4-fold (0.38 log units) above what was measured; the measured number falls inside the stated range.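

In this assay, adding the methyl on the core of compound 3 gives a 1.6-fold lower number from compound 3 to compound 4 (0.21 log units; within the scatter), so on this core the step cannot be told apart from repeat measurement, whereas the earlier step on the other core could. Set side by side, the two results show that this kind of methyl addition does not carry a fixed effect from one core to the other in this series: the same change on two cores in this assay, a 2.6-fold higher number (0.41 log units; beyond the scatter) from compound 1 to compound 2 and a 1.6-fold lower number (0.21 log units; within the scatter) from compound 3 to compound 4, 4.2-fold (0.63 log units) apart, beyond the scatter of two such steps. This does not show that the core alone accounts for the gap, since the carbon receiving the methyl is bound to a double-bonded chain carbon and a saturated chain carbon in the earlier pair but to a double-bonded chain carbon only in the new one, and each core is represented by a single step.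

The compounds shown leave open how the exact same methyl step would behave on both cores, as no matched pair places it on each of them. They also leave open whether a longer chain, or an amine in place of the added methyl, would follow the same course on the two cores.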